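A few compounds are considered here, and "the series" means these few. Any claim that something is new, unique, unknown or untested is made for them only; others in the source may bear on it.

Working notes on the series. Compound 1 `O=c1[nH]c2ccccc2n1CCCN1CCN(S(=O)(=O)c2ccc(F)cc2)CC1` and compound 2 `Cc1ccc2ccn(CCCCN3CCN(C(c4ccccc4)c4ccccc4)CC3)c2c1` have been measured, compound 3 `Fc1cccc2c1ccn2CCCCN1CCN(C(c2ccccc2)c2ccccc2)CC1` has not. In an assay on RPMI-8226 cells for antagonist activity at P2X purinoceptor 7 (Homo sapiens), read by calcium flux (on this read-out higher numbers stand for weaker inhibition and lower numbers for stronger inhibition), compound 1 gives > 10000 nM, a limit of the assay rather than a number. The second value in the set is only that limit (the limit of > 10000 nM in this assay, at which 1 of the 2 values shown sits). In this assay, within the data shown here, compound 2 gives 6500 nM, the only number in the set. Compound 3 differs from compound 2 by a group of 10 heavy atoms (8 carbon, 1 nitrogen, 1 fluorine; one five-membered aromatic ring with 1 hetero atom, one six-membered aromatic ring of carbon only) in place of a group of 10 heavy atoms (9 carbon, 1 nitrogen; one five-membered aromatic ring with 1 hetero atom, one six-membered aromatic ring of carbon only), on a saturated chain carbon, four bonds along the chain from an amine nitrogen in a ring. Among the measured compounds shown here, no measured step of this kind exists, so the expected step is small, of no firm direction, and within the scatter, as a 1.1-fold higher number from compound 2 to compound 3 (0.03 log units; within the scatter). Compound 3 is therefore estimated at 7000 nM in this assay, expected to lie between 2500 nM and 20000 nM.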

Compound 3, half-maximal inhibitory concentration: 150 nM
Compound 3: the middle estimate sits 47-fold (1.67 log units) above what was measured, outside the stated range (below it).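

On a saturated chain carbon, four bonds along the chain from an amine nitrogen in a ring, 4-fluoro-1H-indol-1-yl gives a 43-fold lower number from compound 2 to compound 3 (1.64 log units; beyond the scatter) in this assay. The position therefore responds strongly to a change that leaves the ring types and hydrogen-bond counts of the group unchanged, which compound 1 and compound 2 alone could not show. Nothing in the data given accounts for this step. Open, on these data alone, is whether 1H-indol-1-yl or 4-chloro-1H-indol-1-yl would hold this gain, and whether it survives a shorter chain.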